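From an aromatic group to ethyl on the ring nitrogen

This account rests on a few compounds, and the source may have more. Where it says the series, first, only, none or still open, it means among the compounds named here.

Compound 1 `COc1ccc(N2CCN(C(=O)/C=C/c3ccc(O)c(O)c3)CC2)cc1`: 0.93 ug/mL
Compound 2 `O=C(/C=C/c1ccc(O)c(O)c1)N1CCN(c2ccc([N+](=O)[O-])cc2)CC1`: 1.56 ug/mL
Compound 3 `Cc1ccc(N2CCN(C(=O)/C=C/c3ccc(O)c(O)c3)CC2)c(C)c1`: 1.02 ug/mL
Compound 4 `CCN1CCN(C(=O)/C=C/c2ccc(O)c(O)c2)CC1`: not yet measured

All three values come from a functional assay on A549 cells (Homo sapiens) for antiproliferative activity, read by MTT assay, with a stated time of 48 h (a lower number here means a stronger inhibitor, a higher number a weaker inhibitor), and lie close together. Compound 3 (1.02 ug/mL) cannot be told apart from the other two, since both of its steps (a 1.1-fold higher number from compound 1 to compound 3 (0.04 log units; within the scatter) and a 1.5-fold lower number from compound 2 to compound 3 (0.18 log units; within the scatter)) stay within the scatter.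

The next change is of a different kind. Compound 4 carries ethyl in place of 2,4-dimethylphenyl on an amine nitrogen in a ring. The nearest guides are those two steps and a third (a 1.7-fold higher number from compound 1 to compound 2 (0.22 log units; within the scatter)), but each only swaps one aromatic group for another. Among the measured compounds shown here, no measured compound has lost the aromatic ring, so they give weak support and the range must stay wide. The expected step (a 1.4-fold higher number from compound 3 to compound 4 (0.14 log units; within the scatter)) is therefore none beyond the scatter. Compound 4 is estimated at 1.4 ug/mL (expected range 0.5 ug/mL to 4 ug/mL).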

Compound 4, half-maximal inhibitory concentration: 6.54 ug/mL
Estimate against measurement, compound 4: 4.7-fold (0.67 log units) below, outside the stated range (above it).
By their numbers in this assay, from the lowest: compounds 1, 3 and 2 (each within the scatter of the next); then compound 4.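

In this assay the swaps among aromatic groups on this ring nitrogen all stayed within the scatter, but replacing the aromatic group with ethyl moves the number beyond it in every comparison (a 6.4-fold higher number from compound 3 to compound 4 (0.81 log units; beyond the scatter); a 4.2-fold higher number from compound 2 to compound 4 (0.62 log units; beyond the scatter); a 7.0-fold higher number from compound 1 to compound 4 (0.85 log units; beyond the scatter)). At this position, then, the three aromatic groups cannot be told apart, while ethyl, with no ring and fewer heavy atoms, gives a weaker inhibitor than any of them. No measurement here explains this loss.

The compounds shown leave open whether the aromatic ring itself matters or simply the larger size of the group. A cyclohexyl group, which is a ring but not an aromatic one, or a longer chain such as hexyl, could help separate these two readings.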